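This account rests on a few compounds, and the source may have more. Where it says the series, first, only, none or still open, it means among the compounds named here.

Measured so far:
compound 1 `COC(=O)[C@H](CCSC)NC(=O)c1ccc(C(=O)NC[C@@H]2COc3ccccc3O2)cc1-c1ccccc1C` — 533000 nM
compound 2 `COC(=O)CNC(=O)c1ccc(C(=O)NC[C@H]2COc3ccccc3O2)cc1-c1ccccc1C` — 113000 nM

In a functional assay (HSMC cells, Homo sapiens) for antiproliferative activity, with a stated time of 72 h (on this read-out higher numbers stand for weaker inhibition and lower numbers for stronger inhibition), compound 2 gives 113000 nM, the lowest of the two numbers shown; compound 1 gives the higher number, and the gap between them lies beyond the scatter. Compound 3 `COC(=O)CNC(=O)c1ccc(C(=O)NC[C@@H]2COc3ccccc3O2)cc1-c1ccccc1C` is the next compound in the series. Relative to compound 2, (the two compounds have the same atoms and bonds and differ only in configuration as drawn: 1 of 1 stereo elements differ; a stereocentre at a saturated ring carbon is drawn S in compound 2 and R in compound 3). For the measured compounds named here, no pair of measured compounds differs only in this way, so no measured step supports the size of the change. Inversion at this stereocentre may shift the number in either direction, or leave it within the scatter. Compound 3 is expected at 200000 nM, with a range of 60000 nM to 700000 nM. The step from compound 2 to compound 3 is estimated at a 1.8-fold higher number from compound 2 to compound 3 (0.25 log units; within the scatter), a direction not fixed by any measured comparison.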

Compound 3, half-maximal inhibitory concentration: 89000 nM
Compound 3: the middle estimate sits 2.2-fold (0.35 log units) above what was measured; the range from low to high includes it.
By their numbers in this assay, from the lowest: compounds 3 and 2 (each within the scatter of the next); then compound 1.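

In this assay, inversion at the stereocentre at a saturated ring carbon gives a 1.3-fold lower number from compound 2 to compound 3 (0.10 log units; within the scatter), so the drawn configuration at that carbon does not separate the numbers of this pair. With nothing else changed, hydrogen in place of 2-(methylsulfanyl)ethyl gives a 6.0-fold lower number from compound 1 to compound 3 (0.78 log units; beyond the scatter), which places the gap between compound 1 and compound 3 at that chain rather than at the ring stereocentre. The reading of the stereocentre rests on a single comparison, but one free of any other change: the fact that compounds 2 and 3 differ only in the configuration as drawn

As far as these compounds go, it remains open whether inversion at the ring carbon reads the same when 2-(methylsulfanyl)ethyl is present. Also open, from the compounds shown here alone, is how an amine, a carboxylic acid in place of the methyl ester, or a longer unbranched chain would read in this assay.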